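The source may report more compounds than this note shows. Statements on the series, on what has been measured and on what is new or still open speak of the compounds shown alone.

The measured compounds:
compound 1, `CC1CCN(C2CCN(S(=O)(=O)c3cccc(Br)c3)CC2)CC1`, gives 3.2 nM in a functional assay on DLD-1 cells (Homo sapiens) for antiproliferative activity, read by CellTiter-Glo, with a stated time of 72 h; a lower number here means a stronger inhibitor, a higher number a weaker inhibitor.
compound 3, `COc1ccc(Br)cc1S(=O)(=O)N1CCC(N2CCC(C)CC2)CC1`, gives 2 nM.
compound 2, `CCc1ccc(S(=O)(=O)N2CCC(N3CCC(C)CC3)CC2)cc1`, gives only a limit of the assay, > 5000 nM.

Compound 1 stands at the higher of the two numbers shown, with compound 3 nearest; the step of a 1.6-fold lower number from compound 1 to compound 3 (0.20 log units; within the scatter). The limit for compound 2 is recorded as the limit of > 5000 nM in this assay, at which 1 of the 3 values shown sits. The step of an at least 1500-fold higher number from compound 1 to compound 2 (3.19 log units; beyond the scatter), so the aryl group on the sulfonyl sulfur is a place where a change can cost a great deal.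

Compound 4, `CC1CCN(C2CCN(S(=O)(=O)c3cccc(-c4ccc5ccccc5c4)c3)CC2)CC1`, has not been measured. It differs from compound 1 by naphthalen-2-yl in place of bromo on an aromatic carbon. Both measured steps touch the same aryl group: one shows that a different substitution pattern wipes out the activity, the other that an added methoxy is tolerated. Since the new group is much larger than bromo and sits on the same ring as the bromo that is lost, the author expects a step toward a higher number in this assay, roughly a 47-fold higher number from compound 1 to compound 4 (1.67 log units; beyond the scatter). Compound 4 is therefore estimated at 150 nM, within 10 nM to 2500 nM.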

Compound 4, half-maximal inhibitory concentration: 2 nM
Compound 4: middle estimate off by 75-fold (1.88 log units), on the high side; measured number below the stated range.
By their numbers in this assay, from the lowest: compounds 3, 4 and 1 (each within the scatter of the next). At a limit, above all of these: compound 2.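

In this assay, the step with naphthalen-2-yl in place of bromo is small, a 1.6-fold lower number from compound 1 to compound 4 (0.20 log units; within the scatter), although 10 heavy atoms and 2 aromatic rings enter where 1 heavy atom leaves. The earlier compounds shown here showed only that an added methoxy is tolerated on this ring and that 4-ethylphenyl in place of 3-bromophenyl costs a great deal; compound 4 adds that bromo itself is not required at this position, provided naphthalen-2-yl takes its place. Compound 2 remains the only loss among the compounds shown, and its value is a limit: the limit of > 5000 nM in this assay, at which 1 of the 4 values shown sits.

As far as these compounds go, whether this position also accepts a plain phenyl, an amine or a carboxylic acid remains open. Compound 2 differs from compound 1 both in the group on the ring and in where that group sits. The compounds shown do not separate these two changes.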